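This account rests on a few compounds, and the source may have more. Where it says the series, first, only, none or still open, it means among the compounds named here.

Working notes on the series. Compound 1 `CCCCCCCCCCOc1cccc(OCCCCCCON=C(c2ccc(C(=O)O)cc2)c2ccc(C(=O)O)cc2)c1` carries a single decyloxy group on the shared core and an oxime-ether linker to two benzoic acids. In an assay on isolated protein for binding affinity to P-selectin (Homo sapiens), read by ELISA, tested at 500 uM (a higher number here means more inhibition at the concentration tested (going by the name of the read-out), a lower number less inhibition), compound 1 gives "not determined" (no result reported), so it stands nowhere on the numbers here. Compound 2 `CCCCCCCCCCOc1cc(OCCCCCCCCCC)cc(OCCCCCC(=O)N(c2ccc(C(=O)O)cc2)c2cccc(C(=O)O)c2)c1` carries two decyloxy groups on the core and an amide linker to the two acids. In this assay compound 2 gives 58%.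

Compound 3 `CCCCCCCCCCOc1cc(OCCCCCCCCCC)cc(OCCCCCCON=C(c2ccc(C(=O)O)cc2)c2ccc(C(=O)O)cc2)c1` is the unmeasured member. It differs from compound 1 by decyloxy in place of hydrogen on an aromatic carbon. Among the compounds with values here, no step between measured compounds is given, so the size of this change in this assay cannot be read from the series. Within the data shown here, the only anchor is compound 2, which shares the two decyloxy groups with compound 3. Compound 2 shows moderate inhibition at 58%. Compound 3 is therefore expected to land near that level, with an estimated inhibition of 52% and a range from 20% to 80%.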

Compound 3, a percentage reported as inhibition, at one concentration (the size of the read-out at that concentration, not a potency): 2%
Estimate against measurement, compound 3: 50 percentage points above; measured number outside the range, below it.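

In this assay, within the data shown here, compound 1 gives "not determined" (no result reported) and compound 3 gives 2%, so no step between compound 1 and compound 3 can be read. The compounds shown leave open what the added decyloxy group does in this assay. Nothing available bears on the low value of compound 3.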